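Compound 4 against a series resting on one limit

This account rests on a few compounds, and the source may have more. Where it says the series, first, only, none or still open, it means among the compounds named here.

Of the compounds shown here, three have been read in a functional assay on C8166 cells (Homo sapiens) for antiproliferative activity, read by MTT assay; on this read-out lower numbers stand for higher toxicity in this test and higher numbers for lower toxicity in this test: compound 1 (`Cc1cc(C)cc(S(=O)(=O)c2c(C(=O)NCC(N)=O)[nH]c3ccc(Cl)cc23)c1`), compound 2 (`Cc1cc(C)cc(S(=O)(=O)c2c(C(=O)NCC(=O)NN)[nH]c3ccc(Cl)cc23)c1`) and compound 3 (`Cc1cc(C)cc(S(=O)(=O)c2c(C(=O)NN3CCOC3=O)[nH]c3ccc(Cl)cc23)c1`). Compound 1 gives > 100 uM, which is a limit. Compound 2 gives > 100 uM, also a limit. Compound 3 gives > 100 uM, again a limit. Among the measured compounds shown here, the series therefore stands in one place so far: the limit of > 100 uM in this assay, at which 3 of the 3 values shown sit.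

The next structure is compound 4 (`CNNC(=O)c1[nH]c2ccc(Cl)cc2c1S(=O)(=O)c1cc(C)cc(C)c1`), which keeps the core of compound 3 and carries methylamino in place of 2-oxo-1,3-oxazolidin-3-yl on an amide-type nitrogen.

For the measured compounds named here, three measured steps bear on this change: a step that the two limits leave unreadable from compound 1 to compound 2, a step that the two limits leave unreadable from compound 1 to compound 3 and a step that the two limits leave unreadable from compound 2 to compound 3. None of them has a readable size, so they offer no measured effect of a change at this nitrogen and no direction. They show only that three different side chains all left this assay at the limit. Methylamino has not yet been read in this series, so a number inside the range of the assay remains possible. No step beyond the scatter is expected, and the expected step is a step that the limit leaves unreadable from compound 3 to compound 4. The estimate for compound 4 is 120 uM, with an expected range from 40 uM to 250 uM.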

Compound 4, half-maximal toxic concentration: > 100 uM
Compound 4: no number, only a limit; the forecaster's own chance of this, stated with the estimate: 70%; the middle value lies beyond the limit too.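

In this assay compound 4 gives > 100 uM and this is a limit. With compound 1, compound 2 and compound 3 also at a limit, no step to compound 4 can be read, and the series stays in one place: the limit of > 100 uM in this assay, at which 4 of the 4 values shown sit.

The compounds shown leave open how far beyond this limit any of them lies, and whether any side chain on this amide-type nitrogen gives a number inside the range of the assay.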